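Inverting one stereocentre: compound 2 to compound 3

A few compounds are considered here, and "the series" means these few. Any claim that something is new, unique, unknown or untested is made for them only; others in the source may bear on it.

In an ADME assay on microsomes from liver (Homo sapiens) for metabolic stability, with a stated time of 30 min, tested at 1 uM (a higher number here means that more of the compound is left, a lower number that less of the compound is left), compound 1 `COc1cc(C)c(S(=O)(=O)N(C)CCOCC(=O)N2CCC(N3CCN(C(C)C)CC3)CC2)c(C)c1` gives 54% and compound 2 `COc1cc(C)c(S(=O)(=O)N(C)CCOCC(=O)N2CCN([C@@H]3CN4CCC3CC4)CC2)c(C)c1` gives 57%. For the measured compounds named here, these two numbers lie within the scatter of each other, so compound 2 stands level with the only other measured compound, and neither can be ranked on this read-out.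

Compound 3 `COc1cc(C)c(S(=O)(=O)N(C)CCOCC(=O)N2CCN([C@H]3CN4CCC3CC4)CC2)c(C)c1` is the next case. The change from compound 2 is the two compounds have the same atoms and bonds; at least one stereo element is drawn with a configuration in one of them and without one in the other: 1 of 3 stereo elements differ; a stereocentre at a saturated ring carbon is drawn S in compound 2 and R in compound 3: the two compounds have the same atoms and bonds, and a stereocentre at a saturated ring carbon is drawn S in compound 2 and R in compound 3.

Going by the values given here, no measured pair isolates a stereocentre, so the data offer no direct precedent for the size of this step. The working expectation is therefore no shift beyond the scatter in this assay, with no firm direction, and compound 2 at 57% serves as the anchor. The expected result is a number 2 percentage points lower from compound 2 to compound 3 (within the scatter), and this estimate stays within the scatter. Compound 3 is estimated at 55%, with an expected range of 40% to 70%.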

Compound 3, percent of the compound remaining: 26%
Estimate against measurement, compound 3: 29 percentage points above, and the stated range ends above it.
By their numbers in this assay, from the lowest: compound 3; then compounds 1 and 2 (each within the scatter of the next).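

In this assay the configuration at this saturated ring carbon matters: the series shows a number 31 percentage points lower from compound 2 to compound 3 (beyond the scatter) with no atom or bond changed. For the compounds shown here, this is the only step so far and it lies beyond the scatter, so this read-out separates two compounds that differ in a single drawn stereocentre, with the S form in compound 2 leaving more of the compound than the R form in compound 3. Nothing else in the structures accounts for the step, which rests on one point alone: the fact that one of compounds 2 and 3 is drawn with a defined configuration and the other without, at the place where they differ

The compounds shown leave open whether the gap between the S and R forms persists when a methyl group or a hydroxyl group is placed on that same ring carbon. They also leave open whether the same order of the two forms holds when the methoxy group on the aromatic ring of the shared core is replaced by a carboxylic acid, as one pair of compounds cannot show how general the step is.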